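The source may report more compounds than this note shows. Statements on the series, on what has been measured and on what is new or still open speak of the compounds shown alone.

Measured compounds:
compound 1 `CC(=O)NC[C@H]1CN(c2ccc(OC[C@@H](O)CNc3ccc(C#N)cc3)c(F)c2)C(=O)O1`: 2.12
compound 2 `CC(=O)NC[C@H]1CN(c2ccc(OC[C@H](O)CNc3ccc(C#N)cc3)c(F)c2)C(=O)O1`: 1.29

Both numbers come from a physicochemical assay for lipophilicity, read by HPLC; on this read-out lower numbers stand for lower lipophilicity and higher numbers for higher lipophilicity. Compound 1 stands highest of the two, and its nearest neighbour is compound 2, reached by the step of a number 0.83 log units lower from compound 1 to compound 2 (beyond the scatter). That step rests on (the fact that compounds 1 and 2 differ only in the configuration as drawn), since the two compounds share every atom and bond and differ only in how one stereocentre is drawn.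

Compound 3 `CC(=O)NC[C@H]1CN(c2ccc(OC[C@@H](O)CNC3CC3)c(F)c2)C(=O)O1` has not yet been measured in this assay. It differs from compound 1 in a single place: cyclopropyl in place of 4-cyanophenyl on an amine nitrogen. Within the data shown here, the only measured step available concerns a change of configuration, not the exchange of one group for another, so it offers no direct guide to the size or direction of the present change. The expectation for compound 3 therefore rests on the structural change alone, and the range is set wide to reflect that. For compound 3 the expected step in this assay is a number 1.72 log units lower from compound 1 to compound 3 (beyond the scatter), downward and beyond the scatter. Compound 3 is accordingly estimated at 0.4, within a range from -0.6 to 1.3.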

Compound 3, partition coefficient: 0.02
For compound 3 the middle estimate is 0.38 log units above the measured one; low and high end bracket the measured number.
By their numbers in this assay, from the lowest: compound 3; then compound 2; then compound 1.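

In this assay, the group on the amine nitrogen turns out to carry a great deal of weight: putting cyclopropyl in place of 4-cyanophenyl gives a number 2.10 log units lower from compound 1 to compound 3 (beyond the scatter). The earlier pair showed only that the drawn configuration of one stereocentre moves this number, with a number 0.83 log units lower from compound 1 to compound 2 (beyond the scatter), a modest step, whereas this exchange of one group for another is a large step. The exchange removes several features at once, since 8 heavy atoms, an aromatic ring and a nitrile leave and 3 heavy atoms in a three-membered ring enter, and nothing on hand accounts for the size of the step.

The compounds shown leave open which of these features matters most, and plain phenyl on the same nitrogen would separate the aromatic ring from the nitrile, while cyclohexyl or a longer chain would test the size of a saturated group. They also leave open whether the drawn configuration would move the number in the same direction and by a similar amount with cyclopropyl on the amine nitrogen.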